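A few compounds are considered here, and "the series" means these few. Any claim that something is new, unique, unknown or untested is made for them only; others in the source may bear on it.

Working notes on a small amide series, all tested in an assay on cells for inhibition of sodium- and chloride-dependent glycine transporter 1 (Homo sapiens); a higher number here means that more compound is needed for the effect, a lower number that less compound is needed.

Compound 2 `Cc1cc(C(F)(F)F)ccc1C(=O)NC1(c2ccccc2)CCCN(C)C1` gives 320 nM in this assay. Compound 1 `COc1cc(C(F)(F)F)ccc1C(=O)NC1(c2ccccc2)CCCN(C)C1` gives 4800 nM. The two differ in one place, (methoxy in place of methyl on an aromatic carbon), and the step is a 15-fold higher number from compound 2 to compound 1 (1.18 log units; beyond the scatter).

Compound 3 `COc1cc(C(F)(F)F)cc(SC)c1C(=O)NC1(c2ccc(C)cc2)CCCN(C)C1` gives 230 nM. Its value and that of compound 2 lie within the usual scatter of each other, while the gap to compound 1 lies beyond it. How the core of compound 3 differs from the core of compound 2 is not broken down here.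

Compound 4 `COc1ccc(C2(NC(=O)c3c(OC)cc(C(F)(F)F)cc3SC)CCCN(C)C2)cc1` has not yet been measured. Its difference from compound 3 is methoxy in place of methyl on an aromatic carbon. Within the data shown here, this is the same kind of change as the one from compound 2 to compound 1, not the same: there the methoxy enters ortho to a large group and meta to a trifluoromethyl group, here it enters para to a large group, on the ring that reads 4-methylphenyl to 4-methoxyphenyl. Among the measured compounds shown here, the one measured instance, a 15-fold higher number from compound 2 to compound 1 (1.18 log units; beyond the scatter), therefore cannot be carried over as it stands, and the two rings give no second anchor.

For compound 4 the expected step is a 2.0-fold higher number from compound 3 to compound 4 (0.29 log units; within the scatter), a weaker move in the same direction as the earlier one, resting only on that single precedent at a different place. Compound 4 is estimated at 450 nM, with a range from 150 nM to 1500 nM.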

Compound 4, half-maximal effective concentration: 170 nM
Estimate against measurement, compound 4: 2.6-fold (0.42 log units) above; the measured number falls inside the stated range.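

In this assay, the same replacement of methyl by methoxy, here reading 4-methylphenyl to 4-methoxyphenyl, gives a 1.4-fold lower number from compound 3 to compound 4 (0.13 log units; within the scatter), so the large rise seen in the earlier pair does not recur. Set side by side, the two instances do not agree: the same change on two cores in this assay, a 15-fold higher number (1.18 log units; beyond the scatter) from compound 2 to compound 1 and a 1.4-fold lower number (0.13 log units; within the scatter) from compound 3 to compound 4, 20-fold (1.31 log units) apart, beyond the scatter of two such steps

This shows that, in this series, the name of the change alone does not predict its size, and that a single precedent cannot be carried from one core to another. It does not show what separates the two outcomes, since the pairs differ both in the surrounding core and in the place of the change, and two pairs cannot tell these apart or support a general rule.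

Still open, going by these compounds, is whether the change, made at one fixed place on two different cores, would give matching steps, which would separate the role of the place from that of the core. Also open, on these data alone, is how other groups para to a large group, such as a chlorine, a nitrile or an ethoxy group, would compare with the methyl and methoxy of compound 3 and compound 4.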